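The source may report more compounds than this note shows. Statements on the series, on what has been measured and on what is new or still open speak of the compounds shown alone.

Of the compounds shown here, two sharing one core have been measured so far. Compound 1 `CCCCc1oc2ccccc2c1C(=O)c1ccc(OCC(N)=O)cc1` carries a carbamoylmethyl group, and in a functional assay on U-937 cells (Homo sapiens) for antiproliferative activity, read by MTT assay, with a stated time of 24 h (on this read-out lower numbers stand for stronger inhibition and higher numbers for weaker inhibition), compound 1 gives 42200 nM. Compound 2 `CCCCc1oc2ccccc2c1C(=O)c1ccc(OCC(=O)N2CCCC2)cc1` has pyrrolidin-1-yl in place of amino on that carbonyl carbon, and in this assay compound 2 gives 32500 nM. Among the measured compounds shown here, of these two numbers compound 1 shows the higher one, with compound 2 as its only neighbour, yet the step of a 1.3-fold lower number from compound 1 to compound 2 (0.11 log units; within the scatter) lies within the usual scatter, so the two cannot really be told apart on this read-out.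

Compound 3 `CCCCc1oc2ccccc2c1C(=O)c1ccc(OCC(=O)Nc2ccccc2)cc1` is not yet measured. It differs from compound 1 in one place: phenyl in place of hydrogen on an amide-type nitrogen. For the measured compounds named here, the one measured step that touches the same amide-type nitrogen is a 1.3-fold lower number from compound 1 to compound 2 (0.11 log units; within the scatter), which shows that a larger group on this nitrogen left the number essentially unchanged. On that basis no step beyond the scatter is expected, perhaps a slight drift to a lower number, so the expected step is a 1.4-fold lower number from compound 1 to compound 3 (0.15 log units; within the scatter). Compound 3 is therefore estimated to give 30000 nM in this assay, within a range from 10000 nM to 90000 nM.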

Compound 3, half-maximal inhibitory concentration: 25900 nM
Estimate against measurement, compound 3: 1.2-fold (0.06 log units) above; the measured number falls inside the stated range.
By their numbers in this assay, from the lowest: compounds 3, 2 and 1 (each within the scatter of the next).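

In this assay, among the compounds shown here, phenyl on the amide-type nitrogen gives a 1.6-fold lower number from compound 1 to compound 3 (0.21 log units; within the scatter), so even an aromatic ring at this position, which the earlier pair did not include, produces no step that can be told apart from repeat-measurement noise. Anilino in place of pyrrolidin-1-yl gives a 1.3-fold lower number from compound 2 to compound 3 (0.10 log units; within the scatter), so exchanging the ring-closed group for the aromatic one on the same carbonyl carbon also leaves the read-out unresolved, and the three compounds together show a position that has so far tolerated hydrogen, pyrrolidin-1-yl and phenyl without any measurable difference. No supporting information is available that could explain this flat result.

Going by these compounds, it remains open whether any group on this nitrogen can move the number beyond the scatter, for instance a benzyl group, a piperazine ring or a phenyl ring carrying a carboxylic acid. Also open, on these data alone, is whether the shared core responds more clearly elsewhere, such as when a longer chain or a free amine is placed away from this amide.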